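The source may hold more compounds than are shown below. What is called first, only, known or untested is meant among the compounds shown, and "the series" means these compounds.

Measured compounds: compound 1 `CC(C)n1ncc2c(C(=O)Nc3ccccn3)cc(-c3ccsc3)nc21` with 25000 nM; compound 2 `CC(C)n1ncc2c(C(=O)Nc3cncnc3)cc(-c3cccs3)nc21` with 20000 nM; compound 3 `CC(C)n1ncc2c(C(=O)Nc3ccccc3F)cc(-c3ccncc3)nc21` with 45000 nM.

All three were tested in an ADME assay on LLC-MK2 cells (Macaca mulatta) for cytotoxicity, read by spectrophotometry and crystal violet staining, with a stated time of 4 days; a lower number here means that less compound is tolerated, a higher number that more compound is tolerated. Compound 2 gives the lowest of the three numbers, but compound 1 sits within the scatter of it, and only compound 3 lies beyond the scatter. No two of these compounds differ in a single place, so no step between measured compounds can be computed.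

Compound 4 `CC(C)n1ncc2c(C(=O)Nc3cccc(C(N)=O)c3)cc(-c3cccs3)nc21` is not yet measured. It differs from compound 2 as follows: 3-carbamoylphenyl in place of pyrimidin-5-yl on an amide-type nitrogen. Among the compounds with values here, with no measured step to guide the direction, the expected step of a 1.5-fold higher number from compound 2 to compound 4 (0.18 log units; within the scatter) is small and not beyond the scatter. Compound 4 is therefore estimated at 30000 nM, with a range from 12000 nM to 75000 nM.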

Compound 4, half-maximal cytotoxic concentration: 25000 nM
For compound 4 the middle estimate is 1.2-fold (0.08 log units) above the measured one; low and high end bracket the measured number.
By their numbers in this assay, from the lowest: compounds 2, 1, 4 and 3 (each within the scatter of the next, the first and the last beyond it).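

In this assay, within the data shown here, 3-carbamoylphenyl in place of pyrimidin-5-yl on an amide-type nitrogen gives a 1.3-fold higher number from compound 2 to compound 4 (0.10 log units; within the scatter), the first comparison in this set that isolates a single place. This exchange of a six-membered ring with 2 hetero atoms for a larger carbon-only aromatic group thus leaves compound 2 and compound 4 within the scatter of each other. No available evidence bears on this result.

As far as these compounds go, it remains open whether a carboxylic acid or a primary amine in place of the carbamoyl group would also stay within the scatter. Whether the same exchange would give a similar step in the settings of compound 1 or compound 3 is also unresolved.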